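Nitro placement on the aryl ring of compound 1

This account rests on a few compounds, and the source may have more. Where it says the series, first, only, none or still open, it means among the compounds named here.

Among the measured compounds shown here, compound 1 `CC1=C(/C=C/C(=O)/C=C/c2ccccc2)C(C)(C)CCC1O` gives 8000 nM in a functional assay on CWR22R cells (Homo sapiens) for cytotoxicity, read by MTT assay, with a stated time of 72 h (on this read-out lower numbers stand for stronger inhibition and higher numbers for weaker inhibition), the highest of the two numbers so far; compound 2 `CC1=C(/C=C/C(=O)/C=C/c2cccc([N+](=O)[O-])c2)C(C)(C)CCC1O` gives 1900 nM in this assay. For the measured compounds named here, the single measured step, a 4.2-fold lower number from compound 1 to compound 2 (0.62 log units; beyond the scatter), bears directly on compound 3 `CC1=C(/C=C/C(=O)/C=C/c2ccc([N+](=O)[O-])cc2)C(C)(C)CCC1O`, whose change from compound 1 is nitro in place of hydrogen on an aromatic carbon. Only the place of the entering group differs from that step, so a step in the same direction and of roughly comparable size is expected for compound 3, a 3.2-fold lower number from compound 1 to compound 3 (0.51 log units; beyond the scatter). Compound 3 is estimated at 2500 nM, within 900 nM to 7000 nM.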

Compound 3, half-maximal inhibitory concentration: 4100 nM
Compound 3: the middle estimate sits 1.6-fold (0.21 log units) below what was measured; the measured number falls inside the stated range.
By their numbers in this assay, from the lowest: compound 2; then compounds 3 and 1 (each within the scatter of the next).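

Nitro para to a large group gives a 2.0-fold lower number from compound 1 to compound 3 (0.29 log units; within the scatter) in this assay and so is not separated from compound 1 at this place, whereas a 4.2-fold lower number from compound 1 to compound 2 (0.62 log units; beyond the scatter) stands beyond the scatter. Nitro in place of hydrogen on this ring therefore does not give a step beyond the scatter at every place. Nothing on hand accounts for the difference between the two placements.

From the compounds shown here alone, whether an amine or a carboxylic acid para to a large group would give a step beyond the scatter remains open. Going by these compounds, how a chlorine atom or a methoxy group would compare with nitro at this place is also open.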